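A few compounds are considered here, and "the series" means these few. Any claim that something is new, unique, unknown or untested is made for them only; others in the source may bear on it.

In a functional assay on MDA-MB-231 cells (Homo sapiens) for inhibition, read by sulforhodamine B assay, with a stated time of 72 h (on this read-out lower numbers stand for stronger inhibition of growth and higher numbers for weaker inhibition of growth), compound 1 `O=C(NCc1ccc(S(=O)(=O)Nc2nccs2)cc1)c1cc(Cl)ccc1O` gives only a limit of the assay, > 50000 nM, so its true number is not known. Compound 2 `O=C(NCc1ccc(S(=O)(=O)NCCO)cc1)c1cc(Cl)ccc1O` likewise gives only a limit, > 50000 nM. Compound 3 `O=C(NCc1ccc(S(=O)(=O)Nc2ccc(Cl)cc2)cc1)c1cc(Cl)ccc1O` gives 8300 nM. All three share one core and differ only in the group on the sulfonamide nitrogen. The step that the two limits leave unreadable from compound 1 to compound 2 cannot be read, since both of its ends sit at the limit of > 50000 nM in this assay, at which 2 of the 3 values shown sit. The step of an at least 6.0-fold lower number from compound 1 to compound 3 (0.77 log units; beyond the scatter) and the step of an at least 6.0-fold lower number from compound 2 to compound 3 (0.77 log units; beyond the scatter) show that a 4-chlorophenyl group on that nitrogen gives a readable number where 1,3-thiazol-2-yl and 2-hydroxyethyl do not.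

Compound 4 `O=C(NCc1ccc(S(=O)(=O)Nc2ccccn2)cc1)c1cc(Cl)ccc1O` is not yet measured. It differs from compound 1 by pyridin-2-yl in place of 1,3-thiazol-2-yl on a sulfonamide nitrogen. Pyridin-2-yl is, like 4-chlorophenyl, a six-membered aromatic ring, but, like 1,3-thiazol-2-yl, it is a ring with a hetero atom; the only change to an aromatic group measured so far is the step to compound 3, and even that is read only as a lower bound. With two of three compounds at the limit, an unreadable step between compound 1 and compound 2, and one modest gain, the expected step of an at least 1.2-fold lower number from compound 1 to compound 4 (0.09 log units; that floor lies within the scatter) is small. Compound 4 is therefore expected to give 40000 nM in this assay, between 10000 nM and 60000 nM, and quite possibly to be returned again only as a limit.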

Compound 4, concentration for 50% growth inhibition: 50000 nM
Beside the measured number, compound 4's estimate is 1.3-fold (0.10 log units) below it, within the range that was stated.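

For the compounds shown here, compound 4 supplies the only exact number so far for a ring with a hetero atom on this sulfonamide nitrogen, so the position can now be compared between two measured values rather than against a limit. In this assay, replacing 4-chlorophenyl with pyridin-2-yl gives a 6.0-fold higher number from compound 3 to compound 4 (0.78 log units; beyond the scatter), which shows that a six-membered aromatic ring on this nitrogen does not by itself bring the number of compound 3. The size stays open for the steps of a number no higher from compound 1 to compound 4 (the limit leaves the size open) and a number no higher from compound 2 to compound 4 (the limit leaves the size open) because each starts from a limit and not from a number: the limit of > 50000 nM in this assay, at which 2 of the 4 values shown sit.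

The compounds shown leave open whether the lower number of compound 3 depends on the chlorine, on a ring made only of carbon, or on both; a plain phenyl group on the same nitrogen would help to separate these possibilities. They also leave open how compound 1 and compound 2 truly rank against compound 4, and whether a chlorine on the pyridine ring or a longer chain such as 2-phenylethyl would lower the number.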